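From a Hexyl Amide to a Morpholine Amide

The source may hold more compounds than are shown below. What is called first, only, known or untested is meant among the compounds shown, and "the series" means these compounds.

Of the compounds shown here, two built on one shared core have been tested in a functional assay on the whole organism (strain Wistar) for inhibition, with Rattus norvegicus as the target, read by paw edema, with stated times of 60 min and 1 h, at a dose of 100 mg/kg by the oral route; on this read-out lower numbers stand for less inhibition and higher numbers for more inhibition at the one dose given (going by the name of the read-out). Compound 1 `COc1cc2c(cc1OC)C(CC(=O)N(C)C)CC2` carries a dimethylamino group on the carbonyl carbon, and in this assay compound 1 gives 25%. Compound 2 `CCCCCCNC(=O)CC1CCc2cc(OC)c(OC)cc21` carries hexylamino in that place, and in this assay compound 2 gives 47.6%. On these two numbers compound 2 stands highest, the move being a number 22.6 percentage points higher from compound 1 to compound 2 (beyond the scatter).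

The next compound, compound 3 `COc1cc2c(cc1OC)C(CC(=O)N1CCOCC1)CC2`, differs from compound 2 in one place: morpholin-4-yl in place of hexylamino on a carbonyl carbon. For the measured compounds named here, the only measured step that bears on this change is a number 22.6 percentage points higher from compound 1 to compound 2 (beyond the scatter), which also swapped the group on the carbonyl carbon. Morpholin-4-yl brings no hydrogen-bond donor, so in that respect compound 3 resembles compound 1, whose dimethylamino group likewise lacks the amide hydrogen, more than it resembles compound 2. A downward step of modest size is therefore expected, a number 15.6 percentage points lower from compound 2 to compound 3 (beyond the scatter), though this rests on a single comparison. In this assay compound 3 is expected to give 32%, within a range from 18% to 48%.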

Compound 3, a percentage reported as inhibition, in the whole organism at one dose (the size of the read-out at that dose, not a potency): 15.6%
Compound 3: middle estimate off by 16.4 percentage points, on the high side; the measured number lies below the stated range.
By their numbers in this assay, from the lowest: compounds 3 and 1 (each within the scatter of the next); then compound 2.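

In this assay, morpholin-4-yl in place of hexylamino on the carbonyl carbon gives a number 32 percentage points lower from compound 2 to compound 3 (beyond the scatter), so the group at this place can move the read-out by a large margin, and morpholin-4-yl does not hold the level reached with hexylamino. Set against dimethylamino, the same group gives a number 9.4 percentage points lower from compound 1 to compound 3 (within the scatter), which means that compound 1 and compound 3 cannot be told apart here, and among these three compounds the two amides without the amide hydrogen sit together while hexylamino stands apart. Nothing measured here explains why the number falls with this change.

Hexylamino differs from both other groups in two ways at once, carrying the amide hydrogen and an open chain, so these three compounds cannot show which of the two goes with the higher number. A butylamino or octylamino group would test the length of the chain, while a nitrogen carrying both a methyl and a hexyl group would keep the chain without the amide hydrogen.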